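The source may hold more compounds than are shown below. What is called first, only, known or untested is meant among the compounds shown, and "the series" means these compounds.

Within the data shown here, compound 1, `COc1ccccc1Oc1cncc(C2=CC3CNCC(C2)C3)c1`, stands lowest of the two numbers measured so far in an in vitro assay on SH-SY5Y cells for displacement of a labelled ligand from Neuronal acetylcholine receptor; alpha3/beta4 (Homo sapiens); on this read-out lower numbers stand for stronger inhibition and higher numbers for weaker inhibition. In this assay compound 1 gives 56 nM. Among the measured compounds shown here, the only other measured compound, compound 2, `CN1C[C@H]2C=C(c3cccnc3)C[C@H](C2)C1`, gives 534 nM in this assay, a higher number that lies well beyond the scatter of the method. For the measured compounds named here, compound 2 differs from compound 1 in more than one place, so this pair shows only that the two values stand far apart, not which part of the structure carries the difference.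

Compound 3, `CC(C)Oc1cncc(C2=CC3CNCC(C2)C3)c1`, is not yet measured. It differs from compound 1 in one place: isopropyl in place of 2-methoxyphenyl on an oxygen on an aromatic ring. Going by the values given here, the 2-methoxyphenyl on the oxygen of compound 1 is thus traded for an isopropyl, and no measured pair shows what such a trade does here. Because compound 1 gives 56 nM and nothing measured speaks for the isopropyl, compound 3 is expected to land at a higher number, with the step of a 2.9-fold higher number from compound 1 to compound 3 (0.46 log units; beyond the scatter) expected to be modest but beyond the scatter. Compound 3 is estimated at 160 nM, within a range from 50 nM to 500 nM.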

Compound 3, inhibition constant: 4.8 nM
Beside the measured number, compound 3's estimate is 33-fold (1.52 log units) above it, and the stated range ends above it.
By their numbers in this assay, from the lowest: compound 3; then compound 1; then compound 2.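

Trading the 2-methoxyphenyl for isopropyl on the oxygen on the aromatic ring gives a 12-fold lower number from compound 1 to compound 3 (1.07 log units; beyond the scatter) in this assay and is the first change at a single place that can be read in this series. It shows that this position strongly influences the read-out, and that in this pair an aromatic ring on the oxygen is not required for a low number: isopropyl, a smaller group with no ring and no hydrogen-bond acceptor, gives the stronger inhibition. The data at hand offer no explanation for the size of this step.

A single step replaces the whole group at once, so it cannot separate the effect of losing the aromatic ring from that of losing the methoxy group or of the change in size. A plain phenyl would address the first two of these questions, while methyl, cyclopentyl or a longer chain such as n-butyl on the same oxygen would show how the read-out follows the size and shape of a group without an aromatic ring.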